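Changing the Group on the Ring Nitrogen of Compound 3

This account rests on a few compounds, and the source may have more. Where it says the series, first, only, none or still open, it means among the compounds named here.

Measured so far in an assay on CHO cells for displacement of a labelled ligand from adenosine receptor A3 (Homo sapiens), read by scintillation counting, with a stated time of 120 min, tested at 10 uM; on this read-out higher numbers stand for more inhibition at the one concentration tested (going by the name of the read-out) and lower numbers for less inhibition:
compound 1, `Nc1scc(CN2CCN(c3cccc(Cl)c3Cl)CC2)c1C(=O)c1ccc(Cl)cc1`, gives 0%;
compound 2, `Nc1scc(CN2CCN(c3cc(Cl)cc(Cl)c3)CC2)c1C(=O)c1ccc(Cl)cc1`, gives 1%;
compound 3, `Nc1scc(CN2CCN(C3CCCC3)CC2)c1C(=O)c1ccc(Cl)cc1`, gives 3%.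

All three compounds share one core and differ only in the group carried by the amine nitrogen in a ring. On the numbers shown, compound 3 sits at the top of the three readings, yet the gaps to it, a number 3 percentage points higher from compound 1 to compound 3 (within the scatter) and a number 2 percentage points higher from compound 2 to compound 3 (within the scatter), are both within the scatter, so the three compounds cannot be told apart in this assay. The remaining measured step, a number 1 percentage points higher from compound 1 to compound 2 (within the scatter), is also within the scatter.

Compound 4, `Nc1scc(CN2CCN(c3ccc(F)cc3F)CC2)c1C(=O)c1ccc(Cl)cc1`, is not yet measured. It arises from compound 3 by the change (2,4-difluorophenyl in place of cyclopentyl on an amine nitrogen in a ring). The two steps that bear on it are those in which cyclopentyl replaced a substituted phenyl; neither moved the read-out beyond the scatter, and putting a different substituted phenyl back in is expected to be no different. Compound 4 is therefore expected to show a step of a number 1 percentage points lower from compound 3 to compound 4 (within the scatter), none beyond the scatter. The estimate for compound 4 in this assay is 2%, with a range from -8% to 12%.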

Compound 4, a percentage reported as inhibition, at one concentration (the size of the read-out at that concentration, not a potency): 0%
Beside the measured number, compound 4's estimate is 2 percentage points above it, within the range that was stated.
By their numbers in this assay, from the lowest: compounds 1, 4, 2 and 3 (each within the scatter of the next).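

In this assay, the 2,4-difluorophenyl group brings no step beyond the scatter against any of the three earlier groups: a number 3 percentage points lower from compound 3 to compound 4 (within the scatter), a number 1 percentage points lower from compound 2 to compound 4 (within the scatter) and no change at the digits printed from compound 1 to compound 4 (within the scatter). Among the compounds shown here, the earlier compounds tested only two dichlorophenyl groups and cyclopentyl on the amine nitrogen in a ring, so this result adds a phenyl group carrying fluorine, and the four compounds still cannot be told apart at the one concentration tested. No measurement here explains why the reading stays the same across these groups.

The compounds shown leave open whether a group of another kind on this nitrogen, such as a longer alkyl chain, a benzyl group or a chain ending in a carboxylic acid, would give a reading beyond the scatter of these four. They also leave open whether replacing the 4-chlorophenyl group on the carbonyl of the shared core, for example with an unsubstituted phenyl or a methoxyphenyl, would separate compounds that this single-concentration read-out cannot yet rank.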